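Moving the trifluoromethyl group around the phenyl ring

The compounds below may be only part of what the source reports. "The series", "measured", "known", "first", "only" and "open" are said of these compounds alone.

Compound 1 `Oc1ccc(-c2cc(-c3cccc(F)c3)cc(-c3ccc(O)cc3)n2)cc1` in a functional assay on HeLa cells (Homo sapiens) for inhibition (on this read-out higher numbers stand for weaker inhibition and lower numbers for stronger inhibition), gives a limit of > 50000 nM.
Compound 2 `Oc1ccc(-c2cc(-c3ccccc3C(F)(F)F)cc(-c3ccc(O)cc3)n2)cc1` in this assay gives a limit of > 50000 nM.
Compound 3 `Oc1ccc(-c2cc(-c3cccc(C(F)(F)F)c3)cc(-c3ccc(O)cc3)n2)cc1` in this assay gives a limit of > 50000 nM.

All three measured compounds sit at the same limit, (the limit of > 50000 nM in this assay, at which 3 of the 3 values shown sit), so none of them has a number of its own. Compound 3 therefore stands nowhere that can be ordered against the others. The steps between them, a step that the two limits leave unreadable from compound 1 to compound 2, a step that the two limits leave unreadable from compound 1 to compound 3 and a step that the two limits leave unreadable from compound 2 to compound 3, are all unreadable for the same reason.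

Compound 4 `Oc1ccc(-c2cc(-c3ccc(C(F)(F)F)cc3)cc(-c3ccc(O)cc3)n2)cc1` differs from compound 3 in one place: 4-(trifluoromethyl)phenyl in place of 3-(trifluoromethyl)phenyl on an aromatic carbon. Going by the values given here, no measured step bears on this change in a readable way, since every step among the fluoro- and trifluoromethyl-bearing analogues ends at the limit. The expectation for the step from compound 3 to compound 4 in this assay is therefore no readable movement, and most likely another limit, a step that the limit leaves unreadable from compound 3 to compound 4. Compound 4 is estimated at 60000 nM, with a range from 15000 nM to 300000 nM.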

Compound 4, half-maximal inhibitory concentration: > 50000 nM
Compound 4 gave a limit, no number; the forecaster's own chance of this, stated with the estimate: 85%; the middle value does not contradict the limit.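

Going by these compounds alone, compound 4 ends at the same limit as compound 1, compound 2 and compound 3, so no step to compound 4 can be read: the limit of > 50000 nM in this assay, at which 4 of the 4 values shown sit. The compounds shown leave open whether moving the trifluoromethyl group around the phenyl ring changes inhibition at all in this assay.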